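The source may hold more compounds than are shown below. What is called first, only, known or untested is meant among the compounds shown, and "the series" means these compounds.

Compound 1: `COc1ccc(Nc2ncnc3cc(OC)c(OCCCCC(=O)Nc4ccc(S(N)(=O)=O)cc4)cc23)cc1` — 30200 nM
Compound 2: `NS(=O)(=O)c1ccc(NC(=S)Nc2ccc3ncnc(Nc4ccc(Cl)c(C(F)(F)F)c4)c3c2)cc1` — 11800 nM

In a functional assay on NCI-H1975 cells (Homo sapiens) for antiproliferative activity, read by MTT assay, with a stated time of 72 h (a lower number here means a stronger inhibitor, a higher number a weaker inhibitor), compound 2 gives the lower of the two numbers, and compound 1 gives a number that is higher by a margin beyond the scatter. Compound 3, `CCc1ccc(Nc2ncnc3ccc(NC(=S)Nc4ccc(S(N)(=O)=O)cc4)cc23)cc1`, has not been measured. It differs from compound 2 by a single change: 4-ethylphenyl in place of 4-chloro-3-(trifluoromethyl)phenyl on a nitrogen on an aromatic ring. For the measured compounds named here, no measured pair shows this change, so its effect is unknown from the data. The step is expected to be small, a 1.3-fold higher number from compound 2 to compound 3 (0.10 log units; within the scatter), in either direction, not clearly beyond the scatter. Compound 3 is therefore expected to give about 15000 nM, within 4000 nM to 60000 nM.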

Compound 3, half-maximal inhibitory concentration: 38700 nM
Estimate against measurement, compound 3: 2.6-fold (0.41 log units) below; measured number inside the range.
By their numbers in this assay, from the lowest: compound 2; then compounds 1 and 3 (each within the scatter of the next).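

In this assay the group on a nitrogen on an aromatic ring is not a neutral choice: 4-ethylphenyl in place of 4-chloro-3-(trifluoromethyl)phenyl gives a 3.3-fold higher number from compound 2 to compound 3 (0.52 log units; beyond the scatter) with the rest of the structure unchanged. For the compounds shown here, this is the first measured pair that isolates this place, and the change costs activity here. Nothing measured explains the step.

The compounds shown leave open how 4-chlorophenyl or 3-(trifluoromethyl)phenyl alone would stand on that nitrogen. They also leave open whether the step holds with the thiourea replaced by an amide chain.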